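Swapping Fluoro for Methoxy on the Second Aryl Ring

The source may report more compounds than this note shows. Statements on the series, on what has been measured and on what is new or still open speak of the compounds shown alone.

Compound 1, `O=C(/C=C\Nc1ccc(F)cc1)c1nc(-c2ccc(F)cc2)n2ccccc12`, gives 16900 nM in a functional assay on BT-474 cells (Homo sapiens) for cytotoxicity, read by MTT assay, with a stated time of 48 h; on this read-out higher numbers stand for weaker inhibition and lower numbers for stronger inhibition.
Compound 3, `COc1ccc(N/C=C\C(=O)c2nc(-c3ccc(F)cc3)n3ccccc23)cc1`, gives 15700 nM.
Compound 2, `O=C(/C=C\Nc1ccc2cc[nH]c2c1)c1nc(-c2ccc(C(F)(F)F)cc2)n2ccccc12`, reaches only a limit of the assay, > 30000 nM.

Compound 3 and compound 1 sit within the scatter of each other, as the step of a 1.1-fold lower number from compound 1 to compound 3 (0.03 log units; within the scatter) shows. Compound 4, `COc1ccc(N/C=C\C(=O)c2nc(-c3ccc(OC)cc3)n3ccccc23)cc1`, differs from compound 3 by methoxy in place of fluoro on an aromatic carbon. For the measured compounds named here, the one measured step of the same kind, a 1.1-fold lower number from compound 1 to compound 3 (0.03 log units; within the scatter), made on the other aromatic ring, stayed within the scatter, so no shift beyond the scatter is expected from compound 3 to compound 4: a 1.0-fold higher number from compound 3 to compound 4 (0.01 log units; within the scatter). Compound 4 is therefore estimated at 16000 nM, expected to fall between 7000 nM and 40000 nM.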

Compound 4, half-maximal inhibitory concentration: 15400 nM
Compound 4: middle estimate off by 1.0-fold (0.02 log units), on the high side, and the stated range covers the measured number.
By their numbers in this assay, from the lowest: compounds 4, 3 and 1 (each within the scatter of the next). At a limit, above all of these: compound 2.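

Turning the 4-fluorophenyl into a 4-methoxyphenyl leaves the number in this assay essentially unmoved, with a 1.0-fold lower number from compound 3 to compound 4 (0.01 log units; within the scatter). The same swap has now been read on both aromatic rings, and on neither did it move the number beyond the scatter. Of the compounds shown, only compound 2 sits at a limit of the assay: the limit of > 30000 nM in this assay, at which 1 of the 4 values shown sits.

Going by these compounds, what an amine or a carboxylic acid at this position would do stays open. Also open is which part of compound 2 accounts for its limit, since it differs from the others in more than one place.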